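Series notes: substituted benzyl indoles with acylsemicarbazone link

A few compounds are considered here, and "the series" means these few. Any claim that something is new, unique, unknown or untested is made for them only; others in the source may bear on it.

Two compounds of the series have numbers. Compound 1, `CC1CCN(Cc2ccc3nc(NC(=O)N/N=C/c4cn(Cc5ccccc5Cl)c5ccccc45)sc3c2)CC1`, gives 1360 nM in a functional assay on MDA-MB-231 cells (Homo sapiens) for cytotoxicity, read by MTT assay, with a stated time of 72 h; a lower number here means a stronger inhibitor, a higher number a weaker inhibitor. Compound 2, `CCN(CC)Cc1ccc2nc(NC(=O)N/N=C/c3cn(Cc4ccccc4)c4ccccc34)sc2c1`, gives 1470 nM in this assay. Compound 2 sits on the two numbers shown such that its gap to compound 1 lies within the scatter of the measurement; on these two values compound 2 cannot be told apart from compound 1, and no step between measured compounds that differ in a single place is available.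

Compound 3, `CC1CCN(Cc2ccc3nc(NC(=O)N/N=C/c4cn(Cc5ccccc5)c5ccccc45)sc3c2)CC1`, has not been measured. It differs from compound 2 as follows: 4-methylpiperidin-1-yl in place of diethylamino on a saturated chain carbon bound to an aromatic carbon. Among the measured compounds shown here, no measured pair isolates this change, so the only guide is that compound 1, which carries the entering group on the same saturated chain carbon, and compound 2, which carries the leaving group, give numbers inside the scatter of one another in this assay.

The change is therefore expected to leave the number within the scatter, the expected step being a 1.1-fold lower number from compound 2 to compound 3 (0.02 log units; within the scatter). Compound 3 is estimated at 1400 nM in this assay, with a range from 700 nM to 2800 nM.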

Compound 3, half-maximal inhibitory concentration: 2850 nM
For compound 3 the middle estimate is 2.0-fold (0.31 log units) below the measured one; the whole stated range lies below it.
By their numbers in this assay, from the lowest: compounds 1, 2 and 3 (each within the scatter of the next, the first and the last beyond it).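

In this assay the exchange of diethylamino for 4-methylpiperidin-1-yl on a saturated chain carbon bound to an aromatic carbon now has a measured pair of its own, which reads as a 1.9-fold higher number from compound 2 to compound 3 (0.29 log units; within the scatter) and so does not separate these two groups. Compound 3 also opens a single-place comparison at a second site, hydrogen in place of chloro on an aromatic carbon, which reads as a 2.1-fold higher number from compound 1 to compound 3 (0.32 log units; beyond the scatter) and is a modest step, the only one of the two that lies beyond the scatter. Nothing on hand offers a reason for either step.

Open, going by these compounds, is whether the chloro step carries over to a compound with diethylamino on the chain carbon, and how fluoro or methoxy in place of chloro on that aromatic carbon would read. Equally open, on these data alone, is how a morpholine or a primary amine on the saturated chain carbon would read in this assay against the two groups compared here.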